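The source may hold more compounds than are shown below. What is called first, only, known or untested is meant among the compounds shown, and "the series" means these compounds.

Working notes on the series. Of the compounds shown here, three have been measured in a functional assay for antagonist activity at transient receptor potential cation channel subfamily V member 1 (Homo sapiens), read by FLIPR; a higher number here means a weaker inhibitor, a lower number a stronger inhibitor. Compound 1 `Cc1cccnc1-c1ccc(C(=O)Nc2ccc(C(C)C)cc2)cc1` gives 73 nM; compound 2 `Cc1cccnc1-c1ccc(C(=O)Nc2ccc(C(F)(F)F)cc2)cc1` gives 65 nM; compound 3 `Cc1cccnc1-c1ccc(C(=O)Nc2ccc(C(C)(C)C)cc2)cc1` gives 11 nM. Compound 3 stands lowest of the three, with a 5.9-fold lower number from compound 2 to compound 3 (0.77 log units; beyond the scatter) and a 6.6-fold lower number from compound 1 to compound 3 (0.82 log units; beyond the scatter), both beyond the scatter, so it is the most potent of the set; the step of a 1.1-fold lower number from compound 1 to compound 2 (0.05 log units; within the scatter) lies within the scatter.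

Compound 4 `CC(C)(C)c1ccc(NC(=O)c2ccc(-c3ccccn3)cc2)cc1` differs from compound 3 in one place: hydrogen in place of methyl on an aromatic carbon. Within the data shown here, none of the measured steps bears on this position; all three concern the group on the anilide ring, and they say nothing about the methyl on the pyridine ring. The expectation therefore rests on compound 3 alone, and a step of a 1.8-fold higher number from compound 3 to compound 4 (0.26 log units; within the scatter) in this assay is taken as the working guess, with a wide range in either direction. Compound 4 is estimated at 20 nM, between 6 nM and 70 nM.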

Compound 4, half-maximal inhibitory concentration: 11 nM
Beside the measured number, compound 4's estimate is 1.8-fold (0.26 log units) above it, within the range that was stated.
By their numbers in this assay, from the lowest: compounds 3 and 4 (each within the scatter of the next); then compounds 2 and 1 (each within the scatter of the next).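

Among these compounds, the change from 3-methylpyridin-2-yl to pyridin-2-yl gives no change at the digits printed from compound 3 to compound 4 (within the scatter) in this assay and is the first reading at this position, as the earlier steps all changed another place in the molecule. With tert-butyl held constant, the methyl on this aromatic carbon, two atoms from the ring nitrogen, can be replaced by hydrogen with no shift beyond the scatter, so the low number of compound 3 does not depend on that methyl. No supporting data bear on this result, and it stands as a comparison of the two numbers alone.

Still open, going by these compounds, is how a larger or different group at this carbon would read, such as ethyl, methoxy, chlorine, an amine or a carboxylic acid. Also open, on these data alone, is whether the same change reads alike with trifluoromethyl or isopropyl in place of tert-butyl.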